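From iodo to methoxy on a shared core

A few compounds are considered here, and "the series" means these few. Any claim that something is new, unique, unknown or untested is made for them only; others in the source may bear on it.

Measured in a functional assay on HT-29 cells (Homo sapiens) for cytotoxicity, read by MTT assay; on this read-out higher numbers stand for weaker inhibition and lower numbers for stronger inhibition:
Compound 1 `C=C1C(=O)[C@]23C[C@@]1(O)CC[C@H]2[C@@]12C=CC(=O)[C@](C)(C(=O)O1)[C@H]2[C@@H]3C(=O)OCc1ccccc1`: 83300 nM
Compound 2 `C=C1C(=O)[C@]23C[C@@]1(I)CC[C@H]2[C@@]12C=CC(=O)[C@](C)(C(=O)O1)[C@H]2[C@@H]3C(=O)OCc1ccccc1`: 50200 nM

For the measured compounds named here, compound 2 gives 50200 nM, a number within the scatter of compound 1, the only other compound measured. The next compound, compound 3 `C=C1C(=O)[C@]23C[C@@]1(OC)CC[C@H]2[C@@]12C=CC(=O)[C@](C)(C(=O)O1)[C@H]2[C@@H]3C(=O)OCc1ccccc1`, differs from compound 2 by methoxy in place of iodo on a saturated ring carbon. Going by the values given here, one measured step bears on this change: a 1.7-fold lower number from compound 1 to compound 2 (0.22 log units; within the scatter), iodo in place of hydroxy on that same carbon. With that single step as the guide, no step beyond the scatter is expected in this assay. The expected step is a 1.2-fold higher number from compound 2 to compound 3 (0.08 log units; within the scatter). For compound 3 the estimated value is 60000 nM, with an expected range from 28000 nM to 125000 nM.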

Compound 3, half-maximal inhibitory concentration: 48400 nM
Estimate against measurement, compound 3: 1.2-fold (0.09 log units) above, within the range that was stated.
By their numbers in this assay, from the lowest: compounds 3, 2 and 1 (each within the scatter of the next).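

In this assay, the saturated ring carbon now carries hydroxy, iodo or methoxy, and methoxy in place of iodo gives a 1.0-fold lower number from compound 2 to compound 3 (0.02 log units; within the scatter), while methyl in place of hydrogen on the oxygen gives a 1.7-fold lower number from compound 1 to compound 3 (0.24 log units; within the scatter). Neither change leaves the scatter, so all three groups on this carbon give values within the scatter of one another. Nothing available here accounts for this result.

From the compounds shown here alone, whether an amine or a carboxylic acid on this carbon would also stay within the scatter remains open. So does whether a longer chain on the oxygen would.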